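A few compounds are considered here, and "the series" means these few. Any claim that something is new, unique, unknown or untested is made for them only; others in the source may bear on it.

In an in vitro ADME assay on microsomes from liver (Simiiformes) (on this read-out lower numbers stand for a shorter-lived compound and higher numbers for a longer-lived compound), compound 1 `CCc1cc(CCCOc2c(C)cc(-c3noc(C)n3)cc2C)on1` gives 0.183 h. Compound 2 `Cc1cc(-c2noc(C(F)(F)F)n2)cc(C)c1OCCCc1cc(C[S+](C)[O-])no1` gives > 2.5 h, which is a limit of the assay and not a number. Compound 3 `Cc1cc(-c2noc(C3CC3)n2)cc(C)c1OCCCc1cc(OCCO)no1` gives > 2.5 h, which is also a limit. Compound 3 therefore stands at the limit of > 2.5 h in this assay, at which 2 of the 3 values shown sit. In compound 4 `Cc1cc(CCCOc2c(C)cc(-c3noc(C4CC4)n3)cc2C)on1`, methyl takes the place of 2-hydroxyethoxy on an aromatic carbon (methyl in place of 2-hydroxyethoxy on an aromatic carbon). For the measured compounds named here, no measured pair isolates this change. The expectation rests instead on the measured structure closest to compound 4, which is compound 1 at 0.183 h. A large drop in half-life, well beyond the usual scatter, is expected, with the estimated step of an at least 8.3-fold lower number from compound 3 to compound 4 (0.92 log units; beyond the scatter). For compound 4 the estimate is 0.3 h, with an expected range of 0.12 h to 0.9 h.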

Compound 4, half-life: 2.23 h
Estimate against measurement, compound 4: 7.4-fold (0.87 log units) below, outside the stated range (above it).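

In this assay, placing methyl instead of 2-hydroxyethoxy on this aromatic carbon, next to the ring nitrogen, gives a step that can be stated only as a floor (an at least 1.1-fold lower number from compound 3 to compound 4 (0.04 log units; that floor lies within the scatter)). Compound 4 shows that a half-life of 2.23 h is reached at this position without 2-hydroxyethoxy. Compound 3 has a limit of the assay and not a number: the limit of > 2.5 h in this assay, at which 2 of the 4 values shown sit.

As far as these compounds go, the full size of the step therefore stays open. So does the effect on half-life of an amine, a carboxylic acid or a longer alkoxy chain at this position.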